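Terminal Dimethylcarbamoyl in Place of Methyl on Compound 2

The source may report more compounds than this note shows. Statements on the series, on what has been measured and on what is new or still open speak of the compounds shown alone.

Compound 2 `C=CCc1cc(C(C)=O)c(O)cc1OCCCCCC` stands highest of the two numbers measured: in an assay on isolated protein for inhibition of leukotriene B4 receptor 1 (Homo sapiens), tested at 10 uM (on this read-out lower numbers stand for less inhibition and higher numbers for more inhibition at the one concentration tested (going by the name of the read-out)), compound 2 gives 50%, while compound 1 `C=CCc1cc(C(C)=O)c(O)cc1OCC#N` gives 20%. Among the measured compounds shown here, the only measured step is a number 30 percentage points higher from compound 1 to compound 2 (beyond the scatter), which changed the chain next to the ring oxygen rather than its far end, so it bears on the present change only loosely. Compound 3 `C=CCc1cc(C(C)=O)c(O)cc1OCCCCCC(=O)N(C)C` differs from compound 2 by dimethylcarbamoyl in place of methyl on a saturated chain carbon, five bonds along the chain from an oxygen on an aromatic ring. For the measured compounds named here, with no closer precedent, compound 3 is expected to show a small drop in this assay, a number 12 percentage points lower from compound 2 to compound 3 (beyond the scatter), near the edge of the scatter. Compound 3 is estimated at 38%, ranging from 15% to 62%.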

Compound 3, a percentage reported as inhibition, at one concentration (the size of the read-out at that concentration, not a potency): 92%
For compound 3 the middle estimate is 54 percentage points below the measured one; measured number above the stated range.
By their numbers in this assay, from the lowest: compound 1; then compound 2; then compound 3.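

At the position on a saturated chain carbon, five bonds along the chain from an oxygen on an aromatic ring, this assay responds strongly: dimethylcarbamoyl in place of methyl gives a number 42 percentage points higher from compound 2 to compound 3 (beyond the scatter). Among the compounds shown here, the earlier compounds showed only a change on the chain carbon bound to the ring oxygen, so this is the first sign that the site further along the chain also moves the read-out. No measurement at hand accounts for the gain. From the compounds shown here alone, whether it belongs to the carbonyl, the dimethylamino part or the chain length stays open; a carboxylic acid, a primary amide, an amine or a shorter chain carrying the dimethylcarbamoyl would separate these.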